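The compounds below may be only part of what the source reports. "The series", "measured", "known", "first", "only" and "open" are said of these compounds alone.

For the measured compounds named here, compound 1 `COc1ccc(F)cc1NC(=O)CN1CCN(S(=O)(=O)N2CCC(C)CC2)CC1` is one of three compounds measured in an assay on HEK293 cells for inhibition of potassium channel subfamily T member 1 (Homo sapiens), read by thallium flux (a higher number here means a weaker inhibitor, a lower number a stronger inhibitor), where compound 1 gives 4900 nM. Compound 3 `COc1ccc(Cl)cc1NC(=O)N1CCCN(S(=O)(=O)N2CCC(C)CC2)CC1` sits within the scatter of that figure, as compound 3 gives 6200 nM in this assay; compound 2 `COc1ccc(Cl)cc1NC(=O)CN1CCN(S(=O)(=O)N2CCC(C)CC2)[C@H](C)C1` lies beyond it, with compound 2 at 13000 nM in this assay. Going by the values given here, none of these three differ from one another in a single place, so no isolated step between measured compounds can be read off.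

Compound 4 `COc1ccc(C)cc1NC(=O)CN1CCN(S(=O)(=O)N2CCC(C)CC2)CC1` is derived from compound 1 by one change, methyl in place of fluoro on an aromatic carbon. Among the compounds with values here, nothing among the measured compounds isolates this kind of exchange, so the size of its effect in this assay is uncertain; a small step in either direction, most likely within the scatter, seems reasonable. Compound 4 is therefore expected to give about 5500 nM in this assay, with a plausible range from 2500 nM to 13000 nM. That estimate means a step from compound 1 to compound 4 of a 1.1-fold higher number from compound 1 to compound 4 (0.05 log units; within the scatter), judged to fall within the scatter.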

Compound 4, half-maximal inhibitory concentration: > 10000 nM
Compound 4: only a limit was reported; the forecaster's own chance of this, stated with the estimate: 10%; at least 1.8-fold (0.25 log units) between middle value and limit.
By their numbers in this assay, from the lowest: compounds 1 and 3 (each within the scatter of the next); then compound 2.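

Compound 4 is reported in this assay only as a limit, > 10000 nM. This gives the first exchange isolated at a single place in the series, on the aromatic carbon para to a methoxy group, and replacing fluoro with methyl there comes with an at least 2.0-fold higher number from compound 1 to compound 4 (0.30 log units; that floor lies within the scatter), so this position now has a measured step, which points toward a higher number. That step is only a floor, and its full size cannot be read, as it rests on a limit: the limit of > 10000 nM in this assay, at which 1 of the 4 values shown sits.

The compounds shown leave open how far the number rises with methyl and whether the higher number follows from methyl alone or extends to other groups at this position. A nitrile, a trifluoromethyl group or a plain hydrogen there would test whether fluoro is specifically favoured.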